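Moving the methoxy group on compound 2

A few compounds are considered here, and "the series" means these few. Any claim that something is new, unique, unknown or untested is made for them only; others in the source may bear on it.

In a functional assay on HGC-27 cells (Homo sapiens) for cytotoxicity, read by MTT assay, with a stated time of 48 h (a lower number here means a stronger inhibitor, a higher number a weaker inhibitor), compound 1 (`COc1ccc(/C=C/C(=O)/C=C/c2cc3ccccc3nc2Cl)c(OC)c1`) gives > 10000 nM and this is a limit of the assay. Compound 2 (`COc1ccc(/C=C/C(=O)/C=C/c2cc3ccccc3nc2Oc2ccc(Br)cc2)c(OC)c1`) gives > 10000 nM and this too is a limit. Within the data shown here, the series so far shows the limit of > 10000 nM in this assay, at which 2 of the 2 values shown sit, and no number. The change to compound 3 (`COc1ccc(/C=C/C(=O)/C=C/c2cc3ccccc3nc2Oc2ccc(Br)cc2)cc1OC`) is 3,4-dimethoxyphenyl in place of 2,4-dimethoxyphenyl on a double-bonded chain carbon bound to a double-bonded chain carbon with 3,4-dimethoxyphenyl in place of 2,4-dimethoxyphenyl. Among the measured compounds shown here, the one measured step is a step that the two limits leave unreadable from compound 1 to compound 2 and it lies elsewhere on the molecule, so it offers no size to carry over. The expected step is an at least 1.1-fold lower number from compound 2 to compound 3 (0.04 log units; that floor lies within the scatter) and any estimated move can only run toward a lower number in this assay here. For compound 3 the estimate is 9000 nM within an expected range of 2500 nM to 20000 nM and another limit is quite possible.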

Compound 3, half-maximal inhibitory concentration: > 10000 nM
Compound 3: only a limit was reported (the forecaster's own chance of this, stated with the estimate: 55%); at least 1.1-fold (0.04 log units) between middle value and limit.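

Compound 2 and compound 3 are both reported only as limits, so no step can be read between them. Still open is how 3,4-dimethoxyphenyl and 2,4-dimethoxyphenyl compare in this assay, with the whole series at one limit: the limit of > 10000 nM in this assay, at which 3 of the 3 values shown sit.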